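Bromo to Amino on Two Related Fused Cores

This account rests on a few compounds, and the source may have more. Where it says the series, first, only, none or still open, it means among the compounds named here.

Measured so far in a functional assay on MCF7 cells (Homo sapiens) for antiproliferative activity, read by colorimetric assay and sulforhodamine B assay, with a stated time of 3 days; a lower number here means a stronger inhibitor, a higher number a weaker inhibitor:
compound 1, `Brc1ncnc2c1ncn2CC1CSc2ccccc2O1`: 4870 nM
compound 3, `Brc1ncnc2c1ncn2CC1COc2ccccc2O1`: 7640 nM
compound 2, `Nc1ncnc2c1ncn2CC1CSc2ccccc2O1`, gives only a limit of the assay, > 30000 nM.

Among the compounds with values here, the one measured step in this assay is an at least 6.1-fold higher number from compound 1 to compound 2 (0.78 log units; beyond the scatter), the change being (amino in place of bromo on an aromatic carbon). Its size is bounded by the limit of > 30000 nM in this assay, at which 1 of the 3 values shown sits. Compound 3 and compound 1 differ in their cores; the difference between the two cores is not broken down here, and their numbers in this assay lie within the scatter of each other.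

Compound 4, `Nc1ncnc2c1ncn2CC1COc2ccccc2O1`, carries the same change on the core of compound 3: amino in place of bromo on an aromatic carbon. Within the data shown here, the only guide in this assay is an at least 6.1-fold higher number from compound 1 to compound 2 (0.78 log units; beyond the scatter). A step of the same order is expected, a 5.9-fold higher number from compound 3 to compound 4 (0.77 log units; beyond the scatter), resting only on that single measured step. Compound 4 is therefore estimated at 45000 nM in this assay, with 18000 nM to 120000 nM as the expected range, and a limit rather than a number is the more likely outcome.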

Compound 4, half-maximal inhibitory concentration: > 30000 nM
Compound 4 ended at the assay's limit; the forecaster's own chance of this, stated with the estimate: 70%; the middle value does not contradict the limit.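

In this assay, amino in place of bromo on the core of compound 3 gives an at least 3.9-fold higher number from compound 3 to compound 4 (0.59 log units; beyond the scatter), so the change moves the number the same way on both cores shown. The direction of the change therefore carries from one core to the other: the same change on two cores in this assay, an at least 6.1-fold higher number (0.78 log units; beyond the scatter) from compound 1 to compound 2 and an at least 3.9-fold higher number (0.59 log units; beyond the scatter) from compound 3 to compound 4; the limit leaves it open whether they differ

What does not carry over is a size, since both amino compounds give a limit and not a number: the limit of > 30000 nM in this assay, at which 2 of the 4 values shown sit.

Open, from the compounds shown here alone, is how a chloro, methoxy or methylamino group in the same place would compare with bromo and amino on these cores. Also open, going by these compounds, is whether any such group would give a number on both cores rather than a limit.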